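From Chloro to Methyl in a Growth Test

The source may report more compounds than this note shows. Statements on the series, on what has been measured and on what is new or still open speak of the compounds shown alone.

Compound 1 (`CCOC(=O)c1nn(-c2ccccc2)c(-c2ccc(Cl)cc2)c1CNC(C)(C)C`) is recorded in a functional assay on NCI-H460 cells (Homo sapiens) for inhibition, read by sulforhodamine B assay, with a stated time of 48 h (on this read-out higher numbers stand for weaker inhibition of growth and lower numbers for stronger inhibition of growth), at 69200 nM; > 559000 nM (2 entries). One of these entries is a limit of the assay. Going by the values given here, compound 2 (`CC(C)(C)NCc1c(C(=O)O)nn(-c2ccccc2)c1-c1ccc(Cl)cc1`) gives 70500 nM in this assay and this is the only single number available.

Compound 3 (`Cc1ccc(-c2c(CNC(C)(C)C)c(C(=O)O)nn2-c2ccccc2)cc1`) differs from compound 2 in one place (methyl in place of chloro on an aromatic carbon) with methyl in place of chloro on an aromatic carbon, para to a large group. The same difference reads 4-chlorophenyl to 4-methylphenyl.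

Among the compounds with values here, no measured step guides this change, so nothing beyond the scatter is expected in this assay in either direction. The estimated 1.0-fold higher number from compound 2 to compound 3 (0.01 log units; within the scatter) is expected to be small on that basis. Compound 2 at 70500 nM is the anchor for this expectation. Caution comes from the several entries of compound 1 in this assay, 69200 nM; > 559000 nM (2 entries) where one entry is a limit. Compound 3 is estimated at 72000 nM with an expected range from 30000 nM to 190000 nM as the likely span.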

Compound 3, concentration for 50% growth inhibition: > 688000 nM
Compound 3 was reported as a limit; the forecaster's own chance of this, stated with the estimate: 25%; middle value at least 9.5-fold (0.98 log units) away from the limit.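

In this assay, methyl in place of chloro on an aromatic carbon, para to a large group, gives an at least 9.7-fold higher number from compound 2 to compound 3 (0.98 log units; beyond the scatter), so this position is the first shown to respond to a change. Compound 3 stands at > 688000 nM, which is a limit and not a number. Compound 2 has one further entry without a single number, and entries in this assay can lie far apart: the several entries of compound 1 in this assay, 69200 nM; > 559000 nM (2 entries)

The compounds shown leave open whether this step belongs to methyl alone, or whether fluoro, methoxy or an amine at the same place would read like chloro or like methyl. On these data alone, whether the change from 4-chlorophenyl to 4-methylphenyl reads the same with the ethyl ester of compound 1 in place of the carboxylic acid also remains open.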